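The compounds below may be only part of what the source reports. "The series", "measured", "known", "first", "only" and "open" are said of these compounds alone.

Measured in a functional assay on the whole organism (strain albino) for inhibition, with Rattus norvegicus as the target, read by paw edema, with stated times of 1 h and 0.5 h, at a dose of 100 mg/kg by the oral route; on this read-out higher numbers stand for more inhibition at the one dose given (going by the name of the read-out) and lower numbers for less inhibition:
compound 1 `N#Cc1c(-c2ccc(O)cc2)nc(SCC(=O)Nn2c(COc3ccc(Cl)cc3Cl)nc3ccccc3c2=O)[nH]c1=O` gives 61.5%
compound 2 `Cn1c(SCC(=O)Nn2c(COc3ccc(Cl)cc3Cl)nc3ccccc3c2=O)nc(-c2ccccc2)c(C#N)c1=O` gives 51.9%
compound 3 `Cn1c(SCC(=O)Nn2c(COc3ccc(Cl)cc3Cl)nc3ccccc3c2=O)nc(-c2ccc(Cl)cc2)c(C#N)c1=O` gives 80.8%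

Compound 3 stands highest of the three in this assay; compound 1 is nearest and compound 2 furthest, both gaps beyond the scatter. Compound 4 `Cn1c(SCC(=O)Nn2c(COc3ccc(Cl)cc3Cl)nc3ccccc3c2=O)nc(-c2ccc(O)cc2)c(C#N)c1=O` differs from compound 3 by hydroxy in place of chloro on an aromatic carbon. Among the compounds with values here, one measured step bears on this position: a number 28.9 percentage points higher from compound 2 to compound 3 (beyond the scatter), so the chloro carried a modest gain there. Within the data shown here, compound 1, the only hydroxy-bearing compound, sits on a different core and gives 61.5%, lower than compound 3. Taken together a downward step is expected, a number 20.8 percentage points lower from compound 3 to compound 4 (beyond the scatter), though the change is not a plain reversal of the measured step. Compound 4 is estimated at 60%, within 45% to 75%.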

Compound 4, a percentage reported as inhibition, in the whole organism at one dose (the size of the read-out at that dose, not a potency): 76.9%
Compound 4: middle estimate off by 16.9 percentage points, on the low side; the measured number lies above the stated range.
By their numbers in this assay, from the lowest: compounds 2 and 1 (each within the scatter of the next); then compounds 4 and 3 (each within the scatter of the next).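

In this assay, the aromatic carbon para to a large group takes hydroxy as well as chloro, with a number 3.9 percentage points lower from compound 3 to compound 4 (within the scatter), so the gain over hydrogen is not tied to chloro: the hydroxy step reads a number 25 percentage points higher from compound 2 to compound 4 (beyond the scatter). With 4-hydroxyphenyl held fixed, the ring nitrogen also matters, with methyl in place of hydrogen giving a number 15.4 percentage points higher from compound 1 to compound 4 (beyond the scatter). No measurement available here accounts for either effect.

Open, going by these compounds, is whether an amine or a methoxy group at the same carbon would hold this level. Also open, on these data alone, is how a longer chain in place of methyl on the nitrogen would read.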